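This account rests on a few compounds, and the source may have more. Where it says the series, first, only, none or still open, it means among the compounds named here.

Compound 2 `COc1cc(-c2nn(-c3cccc(NC(=O)c4cccc(C(F)(F)F)c4)c3)cc2-c2ccncc2)ccc1Cl` joins the shared core through an amide to a 3-(trifluoromethyl)phenyl group. In a functional assay on Malme-3M cells (Homo sapiens) for inhibition, read by sulforhodamine B assay, with a stated time of 48 h (a higher number here means a weaker inhibitor of growth, a lower number a stronger inhibitor of growth), compound 2 gives 1990 nM. The two compounds measured beside it are ureas on the same core: compound 1 `O=C(Nc1cccc(-n2cc(-c3ccncc3)c(-c3ccc(Cl)c(O)c3)n2)c1)Nc1cccc(C(F)(F)F)c1` gives 1810 nM in this assay, and compound 3 `O=C(Nc1cccc(-n2cc(-c3ccncc3)c(-c3ccc(Cl)c(O)c3)n2)c1)Nc1ccc(Cl)c(Cl)c1` gives 1190 nM. Both of those numbers lie within the usual scatter of the number for compound 2, so the three cannot be ranked against one another on what is in hand.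

Compound 4 `COc1cc(-c2nn(-c3cccc(NC(=O)c4ccc(Cl)c(C(F)(F)F)c4)c3)cc2-c2ccncc2)ccc1Cl` is the next member awaiting measurement. Its difference from compound 2 is chloro in place of hydrogen on an aromatic carbon. Going by the values given here, the one measured step that touches the same region of the series is a 1.5-fold lower number from compound 1 to compound 3 (0.18 log units; within the scatter), in which the whole aryl on the urea nitrogen is exchanged and the number stays within the scatter. Among the compounds with values here, with only that step to lean on, the added chloro on the amide aryl of compound 4 is expected to leave the number near that of compound 2. For compound 4 the expected shift is a 1.2-fold lower number from compound 2 to compound 4 (0.09 log units; within the scatter). Compound 4 is therefore estimated to give about 1600 nM in this assay, with a range from 700 nM to 3600 nM.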

Compound 4, concentration for 50% growth inhibition: 1180 nM
Estimate against measurement, compound 4: 1.4-fold (0.13 log units) above; low and high end bracket the measured number.
By their numbers in this assay, from the lowest: compounds 4, 3, 1 and 2 (each within the scatter of the next).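

Going by these compounds alone, compound 4 gives the first reading at a single position on the amide aryl: in this assay, placing chloro on the aromatic carbon ortho to a trifluoromethyl group and para to a large group gives a 1.7-fold lower number from compound 2 to compound 4 (0.23 log units; within the scatter). The earlier step, a 1.5-fold lower number from compound 1 to compound 3 (0.18 log units; within the scatter), exchanged the whole aryl on a urea nitrogen and so could not isolate one position, whereas here the added chlorine is the only difference, and the amide series accommodates it with no change that can be told from the scatter. No measurement shown bears on why the number stays within the scatter at this position.

A single substituent leaves open whether this position is insensitive in general, and an amine, a carboxylic acid or a methoxy group in place of the chloro would test that in this assay. Compound 1 and compound 2 differ in more than one place, so the contribution of the amide against the urea, taken apart from the methoxy and hydroxy groups on the chlorophenyl ring, also remains unresolved.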